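This account rests on a few compounds, and the source may have more. Where it says the series, first, only, none or still open, it means among the compounds named here.

Working notes on the series. Three compounds have been run in an ADME assay on HepG2 cells (Homo sapiens) for cytotoxicity, read by luminescence, with a stated time of 72 h; a higher number here means that more compound is needed for the effect, a lower number that less compound is needed: compound 1 `CCOC(=O)c1c(-c2cccc(OC)c2)[nH]c2cc(C(F)(F)F)ccc2c1=O`, compound 2 `CCOC(=O)c1c(-c2cccc(Cl)c2)[nH]c2cc(C(F)(F)F)ccc2c1=O` and compound 3 `CCOC(=O)c1c(-c2cccc(-c3ccccc3)c2)[nH]c2cc(OC)c(OC)cc2c1=O`. In this assay compound 1 gives > 21500 nM, which is a limit of the assay and not a number. Compound 2 gives > 21500 nM, likewise a limit. Compound 3 gives > 21500 nM, again a limit. Compound 1 and compound 2 differ by chloro in place of methoxy on an aromatic carbon, and the step is a step that the two limits leave unreadable from compound 1 to compound 2. All three values sit at the limit of > 21500 nM in this assay, at which 3 of the 3 values shown sit. How the core of compound 1 differs from the core of compound 3 is not broken down here.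

Compound 4 `CCOC(=O)c1c(-c2cccc(-c3ccccc3)c2)[nH]c2cc(Cl)c(OC)cc2c1=O` is not yet measured. It differs from compound 3 by chloro in place of methoxy on an aromatic carbon. This is the same kind of change as that from compound 1 to compound 2, but the place differs: in compound 2 the chloro sits meta to a large group, whereas in compound 4 it sits on a ring that is part of a fused system of two rings, ortho to a methoxy group, meta to a fused ring and para to a fused ring. For compound 4 a step that the limit leaves unreadable from compound 3 to compound 4 is expected, resting on compound 3 sitting at the limit of > 21500 nM in this assay, at which 3 of the 3 values shown sit. The estimate for compound 4 in this assay is 30000 nM, between 12000 nM and 90000 nM.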

Compound 4, half-maximal effective concentration: > 21500 nM
Compound 4 ended at the assay's limit; the forecaster's own chance of this, stated with the estimate: 80%; the middle value lies beyond the limit too.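

Compound 3 and compound 4 both stand at a limit of this assay and not at a number, so no step between them can be read: the limit of > 21500 nM in this assay, at which 4 of the 4 values shown sit.

The compounds shown leave open whether chloro in place of methoxy changes the value in this assay at all, and at what concentration any of the four compounds reaches the half-maximal effect.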